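This account rests on a few compounds, and the source may have more. Where it says the series, first, only, none or still open, it means among the compounds named here.

Measured in an ADME assay for permeability, using PAMPA, with a stated time of 4 h, at pH 5.5; on this read-out lower numbers stand for lower permeability and higher numbers for higher permeability:
- Compound 1 `C/C(CN(C[C@H]1Cc2ccccc2CN1)[C@H]1CCCc2cccnc21)=C(\F)CN`: 280 nm/s
- Compound 2 `C/C(=C/CN)CN(C[C@H]1Cc2ccccc2CN1)[C@H]1CCCc2cccnc21`: 83 nm/s

Compound 2, at 83 nm/s, holds the lower of the two numbers. Compound 3 `N[C@H]1CC[C@@H](N(C[C@H]2Cc3ccccc3CN2)[C@H]2CCCc3cccnc32)CC1` differs from it as follows: a group of 7 heavy atoms (6 carbon, 1 nitrogen; one six-membered non-aromatic ring of carbon only) in place of a group of 6 heavy atoms (5 carbon, 1 nitrogen; no ring), on an amine nitrogen. Going by the values given here, only one measured step bears on this change, and it is modest: a 3.4-fold lower number from compound 1 to compound 2 (0.53 log units; beyond the scatter). That step alters a different open-chain group and gives no direction for a change to a ring, so no step beyond the scatter is expected in this assay. The expected step is a 1.3-fold higher number from compound 2 to compound 3 (0.12 log units; within the scatter). Compound 3 is estimated at 110 nm/s, within an expected range of 40 nm/s to 300 nm/s.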

Compound 3, apparent permeability: 10 nm/s
Compound 3: middle estimate off by 11-fold (1.04 log units), on the high side; the whole stated range lies above it.
By their numbers in this assay, from the lowest: compound 3; then compound 2; then compound 1.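

In this assay, the group on this amine nitrogen proves able to shift the number strongly: 4-aminocyclohexyl in place of the open chain gives an 8.3-fold lower number from compound 2 to compound 3 (0.92 log units; beyond the scatter) and, set against the fluorinated chain, a 28-fold lower number from compound 1 to compound 3 (1.45 log units; beyond the scatter) in the same direction. The entering and leaving groups have equal donor and acceptor counts, so those counts do not account for the fall. No measurement available here explains this fall. As far as these compounds go, whether it follows from the ring or from its amine stays open. A plain cyclohexyl group, or a saturated open chain ending in an amine, would separate the two.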